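Hydroxy for Acetyl on a Diaryl Urea Core

The source may report more compounds than this note shows. Statements on the series, on what has been measured and on what is new or still open speak of the compounds shown alone.

Measured compounds:
- compound 1, `CC(=O)c1ccc(NC(=O)Nc2cc(C)nc3ccccc23)cc1`: 3800 nM
- compound 2, `Cc1cc(NC(=O)Nc2ccc3[nH]cnc3c2)c2ccccc2n1`: 7300 nM
- compound 3, `CSc1ccccc1NC(=O)Nc1cc(C)nc2ccccc12`: 21000 nM

Three ureas sharing the core of compound 1 have been examined in a physicochemical assay for solubility, at pH 7.4; on this read-out lower numbers stand for lower solubility and higher numbers for higher solubility. Compound 1 stands lowest of the three numbers. Compound 2, with 7300 nM, lies within the scatter of compound 1, so no order between the two can be claimed. For the measured compounds named here, compound 3, at 21000 nM, is the only one whose gap to compound 1 falls beyond the scatter.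

Compound 4, `Cc1cc(NC(=O)Nc2ccc(O)cc2)c2ccccc2n1`, has not yet been measured in this assay. It differs from compound 1 in one place: hydroxy in place of acetyl on an aromatic carbon

Going by the values given here, no step between two measured compounds describes this change, so the expectation rests on the spread of the three values. Because compound 2 gives 7300 nM, within the scatter of compound 1, and compound 3 gives 21000 nM, a modest upward move is expected for compound 4, though one that may well stay within the scatter. The step that this estimate means, a 1.6-fold higher number from compound 1 to compound 4 (0.20 log units; within the scatter), is expected to be small and upward. Compound 4 is therefore estimated at 6000 nM, with a range from 2000 nM to 18000 nM.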

Compound 4, solubility: 100 nM
Compound 4: the middle estimate sits 60-fold (1.78 log units) above what was measured, and the stated range ends above it.
By their numbers in this assay, from the lowest: compound 4; then compounds 1 and 2 (each within the scatter of the next); then compound 3.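

In this assay, this position, on an aromatic carbon para to a large group, turns out to be far from neutral: hydroxy in place of acetyl gives a 38-fold lower number from compound 1 to compound 4 (1.58 log units; beyond the scatter), a large step beyond the scatter. For the compounds shown here, the earlier compounds offered no step between two measured compounds that differ in one place, so this pair is the first direct reading of what a change at this position can do. It shows that exchanging acetyl, with 3 heavy atoms and no hydrogen-bond donor, for hydroxy, with 1 heavy atom and 1 hydrogen-bond donor, can go with a steep fall in the number, though nothing available here explains why it falls so far.

A single step cannot separate what goes with the departure of acetyl from what goes with the arrival of hydroxy, and a methoxy group, an amine or a carboxylic acid on the same aromatic carbon would be needed to tell the two apart. Whether the same exchange gives a step of this size on any other urea also remains open, as compound 1 and compound 4 are the only pair of this kind shown.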